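Furan for thiophene on a nucleoside core: an expected inactive

This account rests on a few compounds, and the source may have more. Where it says the series, first, only, none or still open, it means among the compounds named here.

Measured so far:
Compound 1 `CN(C)c1ncnc2c1c(-c1ccoc1)cn2[C@@H]1O[C@H](CO)[C@@H](O)[C@H]1O` gives > 20000 nM, a limit of the assay.
Compound 2 `CN(C)c1ncnc2c1c(-c1cccs1)cn2[C@@H]1O[C@H](CO)[C@@H](O)[C@H]1O` gives > 20000 nM, a limit of the assay.
Compound 3 `Nc1nc(N)c2c(-c3cccs3)cn([C@@H]3O[C@H](CO)[C@@H](O)[C@H]3O)c2n1` gives > 20000 nM, a limit of the assay.

All three compounds were tested in a functional assay on CEM-DNR-bulk cells (Homo sapiens), read by MTT assay, with a stated time of 72 h; a lower number here means a stronger inhibitor, a higher number a weaker inhibitor. None of them gave a number: every one of the three reported values is a limit of the assay, as the limit of > 20000 nM in this assay, at which 3 of the 3 values shown sit, sums up. From compound 2 to compound 1 the change is furan-3-yl in place of thiophen-2-yl on an aromatic carbon; the step that the two limits leave unreadable from compound 2 to compound 1 cannot be read, because both ends of it sit at the limit. How the core of compound 3 differs from that of compound 2 is not broken down here.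

Compound 4 `Nc1nc(N)c2c(-c3ccoc3)cn([C@@H]3O[C@H](CO)[C@@H](O)[C@H]3O)c2n1` has not yet been measured in this assay. Going by the values given here, it differs from compound 3 by furan-3-yl in place of thiophen-2-yl on an aromatic carbon, which is the same change, at the same place, as the one from compound 2 to compound 1. On that change the measured pair gives no readable size, and compound 3 itself is known only as a limit. The expectation therefore rests on the fact that compound 3 sits at the limit > 20000 nM and that the same change left compound 1 at a limit as well. The step that the limit leaves unreadable from compound 3 to compound 4 is thus expected to be nothing that the assay can resolve. Compound 4 is estimated at 30000 nM, with a range from 15000 nM to 100000 nM, and most likely the assay will again report only a limit.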

Compound 4, half-maximal inhibitory concentration: > 20000 nM
Compound 4: no number, only a limit (the forecaster's own chance of this, stated with the estimate: 85%); the middle value does not contradict the limit.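

In this assay compound 4 gives > 20000 nM, which is a limit of the assay and not a number. No size can be read for the change from compound 3 to compound 4, because both compounds stand at the same limit: the limit of > 20000 nM in this assay, at which 4 of the 4 values shown sit.

The compounds shown leave open whether furan-3-yl and thiophen-2-yl differ at all on either core, as none of the four has a measured number in this assay.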